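This account rests on a few compounds, and the source may have more. Where it says the series, first, only, none or still open, it means among the compounds named here.

Compound 1 `CC(C)S(=O)(=O)c1ccc(S(=O)(=O)N2CCC[C@@H](C(=O)N3CCC(F)(F)CC3)C2)cc1` gives 11 nM in a functional assay on MIA PaCa-2 cells (Homo sapiens) for inhibition, read by MTT assay, with a stated time of 7 days; a higher number here means a weaker inhibitor, a lower number a stronger inhibitor. Compound 3 `CCN(CC)C(=O)c1ccc(S(=O)(=O)N2CCC[C@@H](C(=O)N3CCC(F)(F)CC3)C2)cc1` gives 70 nM. Compound 2 `CCN(CC)S(=O)(=O)c1ccc(S(=O)(=O)N2CCC[C@@H](C(=O)NC3CCOCC3)C2)cc1` gives 3770 nM.

Compound 2 therefore gives the highest number of the three; compound 1 and compound 3 both give far lower numbers. Compound 4 `CCN(CC)S(=O)(=O)c1ccc(S(=O)(=O)N2CCC[C@@H](C(=O)N3CC[C@H](OC)C3)C2)cc1` differs from compound 2 by 3-methoxypyrrolidin-1-yl in place of (oxan-4-yl)amino on a carbonyl carbon. For the measured compounds named here, the only measured step, a 6.4-fold higher number from compound 1 to compound 3 (0.80 log units; beyond the scatter), alters a group on the aromatic ring and does not touch the carbonyl carbon, so no measured step bears directly on this change. Still, compound 1 and compound 3 both lack the hydrogen-bond donor that compound 2 carries, and both give much lower numbers, although each also differs elsewhere. Compound 4 is thus expected to give a lower number, a step of a 9.4-fold lower number from compound 2 to compound 4 (0.97 log units; beyond the scatter). Compound 4 is estimated at 400 nM, within 80 nM to 2000 nM.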

Compound 4, half-maximal inhibitory concentration: 2460 nM
Compound 4: the middle estimate sits 6.2-fold (0.79 log units) below what was measured, outside the stated range (above it).
By their numbers in this assay, from the lowest: compound 1; then compound 3; then compounds 4 and 2 (each within the scatter of the next).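

Replacing (oxan-4-yl)amino with 3-methoxypyrrolidin-1-yl on this carbonyl carbon gives a 1.5-fold lower number from compound 2 to compound 4 (0.19 log units; within the scatter) in this assay. The entering group has no hydrogen-bond donor and a five-membered rather than a six-membered ring, yet with the rest of the molecule held constant, this exchange does not move the number beyond the scatter. No measured evidence bears on why the two groups read alike. Still open, as far as these compounds go, is whether a morpholin-4-yl or dimethylamino group on this carbonyl carbon would move the number beyond the scatter.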